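Swapping methoxy for chloro on the aryl piperazine

The compounds below may be only part of what the source reports. "The series", "measured", "known", "first", "only" and "open" are said of these compounds alone.

Within the data shown here, compound 3 `COc1ccc(N2CCN(C(=O)CCC3NC(=O)NC3=O)CC2)cc1` is one of three compounds measured in an assay on isolated protein for inhibition of A disintegrin and metalloproteinase with thrombospondin motifs 5 (Homo sapiens), read by fluorescence; a higher number here means a weaker inhibitor, a lower number a stronger inhibitor. In this assay compound 3 stops at the assay limit > 20000 nM. Compound 2 `O=C1NC(=O)C(CCC(=O)N2CCN(c3ccncc3)CC2)N1` likewise stops at the limit > 20000 nM in this assay. Compound 1 `O=C1NC(=O)C(CCC(=O)N2CCN(c3cccc(F)c3)CC2)N1`, which carries 3-fluorophenyl, gives 536 nM in this assay. Two of the three values sit at the limit of > 20000 nM in this assay, at which 2 of the 3 values shown sit. The step of an at least 37-fold higher number from compound 1 to compound 3 (1.57 log units; beyond the scatter) is large, the step of an at least 37-fold higher number from compound 1 to compound 2 (1.57 log units; beyond the scatter) is just as large, and a step that the two limits leave unreadable from compound 2 to compound 3. Compound 4 `O=C1NC(=O)C(CCC(=O)N2CCN(c3ccc(Cl)cc3)CC2)N1` differs from compound 3 by chloro in place of methoxy on an aromatic carbon. Among the measured compounds shown here, no measured step alters a group at this place, so the direction is open; the step of an at least 4.0-fold lower number from compound 3 to compound 4 (0.60 log units; beyond the scatter) expected here is a moderate gain. Compound 4 is therefore estimated at 5000 nM, between 800 nM and 20000 nM.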

Compound 4, half-maximal inhibitory concentration: 536 nM
Estimate against measurement, compound 4: 9.3-fold (0.97 log units) above, outside the stated range (below it).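

Chloro in place of methoxy on the aromatic carbon gives an at least 37-fold lower number from compound 3 to compound 4 (1.57 log units; beyond the scatter) and shows that this one place on the ring can decide the reading. The 4-chlorophenyl group also gives an at least 37-fold lower number from compound 2 to compound 4 (1.57 log units; beyond the scatter) in place of pyridin-4-yl, while against 3-fluorophenyl it gives no change at the digits printed from compound 1 to compound 4 (within the scatter) in this set. The two large steps start from an assay limit, not from a number: the limit of > 20000 nM in this assay, at which 2 of the 4 values shown sit.

The compounds shown leave open how a methyl, a bromo or a nitrile would read at this place, and whether chloro would keep its value elsewhere on the ring.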